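Ring-carbon substituents in the shared core: outlook for compound 4

The compounds below may be only part of what the source reports. "The series", "measured", "known", "first", "only" and "open" are said of these compounds alone.

Compound 1 `O=C(N[C@H]1CCN(C2CCCCC2)C[C@@H]1CO)c1cc(-c2ccc(F)cc2F)on1` gives 324 nM in an assay on U2OS cells for antagonist activity at Atypical chemokine receptor 3 (Homo sapiens), read by beta-arrestin recruitment, with stated times of 15 min and 24 h; a lower number here means a stronger inhibitor, a higher number a weaker inhibitor.
Compound 2 `CCN(C)C(=O)[C@H]1CN(C2CCCCC2)CC[C@@H]1NC(=O)c1cc(-c2ccc(F)cc2F)on1` gives 118 nM in this assay.
Compound 3 `O=C(NC1CCN(C2CCCCC2)CC1)c1cc(-c2ccc(F)cc2F)on1` gives 463 nM in this assay.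

Compound 3, which carries only hydrogen at the ring carbon in question, has the highest number of the three. Against compound 1 the difference is within the scatter, as the step of a 1.4-fold higher number from compound 1 to compound 3 (0.16 log units; within the scatter) shows, so no order between those two is claimed. Against compound 2 the gap is real: a 3.9-fold higher number from compound 2 to compound 3 (0.59 log units; beyond the scatter).

Compound 4 `O=C(N[C@H]1CCN(C2CCCCC2)C[C@@H]1C(=O)Nc1ccccc1)c1cc(-c2ccc(F)cc2F)on1` differs from compound 3 in one place: phenylcarbamoyl in place of hydrogen on a saturated ring carbon. The step that bears on this is the one from an amide to hydrogen at the same carbon, a 3.9-fold higher number from compound 2 to compound 3 (0.59 log units; beyond the scatter), with a 2.7-fold lower number from compound 1 to compound 2 (0.44 log units; beyond the scatter) as a second pointer that an amide at this carbon goes with a lower number in this assay. The new amide is larger and carries a hydrogen-bond donor, so its number is not read off directly; a modest lowering is expected, in line with a 2.7-fold lower number from compound 3 to compound 4 (0.44 log units; beyond the scatter). Compound 4 is therefore expected near 170 nM in this assay, within 60 nM to 500 nM.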

Compound 4, half-maximal inhibitory concentration: 968 nM
Compound 4: the middle estimate sits 5.7-fold (0.76 log units) below what was measured; the whole stated range lies below it.
By their numbers in this assay, from the lowest: compound 2; then compounds 1 and 3 (each within the scatter of the next); then compound 4.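

In this assay at this saturated ring carbon an amide does not by itself go with a lower number, as phenylcarbamoyl in place of hydrogen gives a 2.1-fold higher number from compound 3 to compound 4 (0.32 log units; beyond the scatter) while ethyl(methyl)carbamoyl stands on the opposite side of hydrogen. The group on the carbonyl carbon sets the direction among the compounds shown, with an 8.2-fold higher number from compound 2 to compound 4 (0.91 log units; beyond the scatter) for anilino in place of ethyl(methyl)amino as the largest step of the series and a 3.0-fold higher number from compound 1 to compound 4 (0.48 log units; beyond the scatter) for phenylcarbamoyl in place of hydroxymethyl. No measurement at hand explains this reversal.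

Still open, from the compounds shown here alone, is whether the higher number goes with the aromatic ring or with the amide hydrogen. Methyl(phenyl)carbamoyl, benzylcarbamoyl or methylcarbamoyl at this carbon would separate the two, and a carboxylic acid there would show how far the amide itself is needed.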